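A Polar Side Chain in Place of Methyl on the Core

The source may hold more compounds than are shown below. What is called first, only, known or untested is meant among the compounds shown, and "the series" means these compounds.

Measured compounds: compound 1 `Nc1nc(O)c2c(n1)n(C1OC(CO)[C@@H](O)[C@H]1O)c(=O)n2C/C=C/c1ccccc1` gives 103 uM; compound 2 `N#Cc1cccc(Cn2c(=O)n(C3OC(CO)[C@@H](O)[C@H]3O)c3nc(N)nc(O)c32)c1` gives 3 uM; compound 3 `CCn1c(=O)n(C2OC(CO)[C@@H](O)[C@H]2O)c2nc(N)nc(O)c21` gives 15 uM, all in a functional assay (B cells) with Mus musculus as the target; on this read-out lower numbers stand for an effect already at smaller amounts and higher numbers for an effect only at larger amounts of compound.

Compound 3 stands second highest of the three numbers. From compound 1 the change to methyl brought a 6.9-fold lower number from compound 1 to compound 3 (0.84 log units; beyond the scatter), while a 5.0-fold higher number from compound 2 to compound 3 (0.70 log units; beyond the scatter) separates it from compound 2. Compound 4 `NCC(O)Cn1c(=O)n(C2OC(CO)[C@@H](O)[C@H]2O)c2nc(N)nc(O)c21` carries 2-amino-1-hydroxyethyl in place of methyl on a saturated chain carbon bound to an aromatic nitrogen. Both measured steps touch the same saturated chain carbon, and both are modest to large, so this position clearly moves this assay; yet neither step involves a group resembling 2-amino-1-hydroxyethyl, so direction is uncertain. For compound 4 the expected step is no change at the digits printed from compound 3 to compound 4 (within the scatter), essentially none beyond the scatter, with a wide range. Compound 4 is estimated at 15 uM, between 4 uM and 60 uM.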

Compound 4, concentration for half-maximal effect: 28 uM
Estimate against measurement, compound 4: 1.9-fold (0.27 log units) below, within the range that was stated.
By their numbers in this assay, from the lowest: compound 2; then compounds 3 and 4 (each within the scatter of the next); then compound 1.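

With 2-amino-1-hydroxyethyl in place of methyl on a saturated chain carbon bound to an aromatic nitrogen, this assay shows a 1.9-fold higher number from compound 3 to compound 4 (0.27 log units; within the scatter) and so no change that can be told from the scatter, even with an amine and a hydroxyl now on the chain. The same chain in place of 3-cyanophenyl gives a 9.3-fold higher number from compound 2 to compound 4 (0.97 log units; beyond the scatter) while in place of 2-phenylethenyl it gives a 3.7-fold lower number from compound 1 to compound 4 (0.57 log units; beyond the scatter) and so compound 4 sits with compound 3 in the middle of the series. Nothing available explains these numbers. Going by these compounds, whether the amine and the hydroxyl each count alone stays open, as does how a carboxylic acid or a longer plain alkyl chain would read here.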